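Compound 3 and its counterpart without a drawn configuration

The compounds below may be only part of what the source reports. "The series", "measured", "known", "first", "only" and "open" are said of these compounds alone.

Measured in a functional assay, with a stated time of 30 min (a higher number here means a weaker inhibitor, a lower number a stronger inhibitor), all three values being limits:
compound 1 `COC(=O)c1c(C(=O)c2c(O)cc(C)cc2OC)c(OC)cc(O)c1[S@@+](C)[O-]`: > 100000 nM
compound 2 `COC(=O)c1c(C(=O)c2c(O)cc(C)cc2OC)c(OC)cc(O)c1[S+](C)[O-]`: > 100000 nM
compound 3 `COC(=O)c1c2c(cc(OC)c1C(=O)c1c(O)cc(C)cc1OC)O[C@H](OC)CS2`: > 100000 nM

Compound 3 stands at > 100000 nM, which is a limit and gives no number to start from. Compound 4 `COC(=O)c1c2c(cc(OC)c1C(=O)c1c(O)cc(C)cc1OC)OC(OC)CS2` is still to be measured. Its difference from compound 3 is this: the two compounds have the same atoms and bonds; at least one stereo element is drawn with a configuration in one of them and without one in the other: 1 of 1 stereo elements differ; a stereocentre at a saturated ring carbon is drawn S in compound 3 and without a configuration in compound 4.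

Going by the values given here, the only measured step of this type is a step that the two limits leave unreadable from compound 1 to compound 2. There the stereocentre is at a sulfur rather than a ring carbon, and the pair is separated only by the fact that one of compounds 1 and 2 is drawn with a defined configuration and the other without, at the place where they differ. The overall picture is the limit of > 100000 nM in this assay, at which 3 of the 3 values shown sit, so the series offers no readable step from a drawn configuration alone. With compound 3 at > 100000 nM, no step beyond the scatter is expected in this assay, and another limit is the likely report. The expected step is a step that the limit leaves unreadable from compound 3 to compound 4, an estimate only. Compound 4 is expected at 150000 nM, with an estimated range of 60000 nM to 400000 nM.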

Compound 4, half-maximal inhibitory concentration: > 100000 nM
Compound 4: a limit, no number; the forecaster's own chance of this, stated with the estimate: 90%; the middle value does not contradict the limit.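

In this assay compound 4 gives > 100000 nM, which is a limit. Compound 3 also stands at a limit, and no step can be read between compound 3 and compound 4. The compounds shown leave open whether the configuration at the saturated ring carbon affects inhibition at all.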